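The source may report more compounds than this note shows. Statements on the series, on what has been measured and on what is new or still open speak of the compounds shown alone.

Three compounds of one shared core had been tested in an ADME assay on HeLa cells (Homo sapiens) for cytotoxicity, read by ATP content, with a stated time of 3 days (a higher number here means that more compound is tolerated, a lower number that less compound is tolerated), before compound 4 came up. Compound 1 `CS(=O)(=O)CCCn1c(Cn2c(=O)n(C3CC3)c3ccncc32)cc2cc(Cl)ccc21` carries a methylsulfonyl group on a saturated chain carbon, three bonds along the chain from an aromatic nitrogen. In this assay compound 1 gives only a limit, > 50000 nM. Compound 2 `N=C(CCCn1c(Cn2c(=O)n(C3CC3)c3ccncc32)cc2cc(Cl)ccc21)NO` gives in this assay likewise only a limit, > 50000 nM. Compound 3 `N#CCCCn1c(Cn2c(=O)n(C3CC3)c3ccncc32)cc2cc(Cl)ccc21`, with a cyano group at the same place, gives in this assay again only a limit, > 50000 nM. Compound 3 therefore stands where every measured compound stands: at the limit of > 50000 nM in this assay, at which 3 of the 3 values shown sit.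

Compound 4 `CC(C)(O)CCCn1c(Cn2c(=O)n(C3CC3)c3ccncc32)cc2cc(Cl)ccc21` differs from compound 3 in one place: 1-hydroxy-1-methylethyl in place of cyano on a saturated chain carbon, three bonds along the chain from an aromatic nitrogen. The measured steps that change that same place are a step that the two limits leave unreadable from compound 1 to compound 2, a step that the two limits leave unreadable from compound 1 to compound 3 and a step that the two limits leave unreadable from compound 2 to compound 3; each of them is unreadable in size, since both ends sit at the limit. Among the measured compounds shown here, no measured step therefore gives a direction or a size for the change from cyano to 1-hydroxy-1-methylethyl.

With three limits and nothing else, compound 4 is expected to remain at the limit as well, so that the step that the limit leaves unreadable from compound 3 to compound 4 is estimated to be none beyond the scatter. Compound 4 is estimated at 60000 nM, within a range from 30000 nM to 200000 nM.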

Compound 4, half-maximal cytotoxic concentration: > 50000 nM
Compound 4: no number, only a limit; the forecaster's own chance of this, stated with the estimate: 85%; the middle value does not contradict the limit.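

In this assay compound 4 gives > 50000 nM as a limit and not a number. No new step can be read, and the steps to compound 4 from compound 1, compound 2 and compound 3 stay unreadable in size: the limit of > 50000 nM in this assay, at which 4 of the 4 values shown sit.

The compounds shown leave open what the half-maximal cytotoxic concentration of any of them is, and whether the groups at this place differ at all.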